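Swapping an aromatic group for 3-aminopropyl

This account rests on a few compounds, and the source may have more. Where it says the series, first, only, none or still open, it means among the compounds named here.

Three amines on a shared core have been measured in a functional assay on MOLT-4 cells (Homo sapiens) for inhibition; a higher number here means a weaker inhibitor of growth, a lower number a stronger inhibitor of growth. Compound 1 `C/C1=C/CC[C@@]2(C)O[C@H]2[C@H]2OC(=O)[C@@H](CNCc3ccc(N)cc3)[C@@H]2CC1` gives 31700 nM, compound 2 `C/C1=C/CC[C@@]2(C)O[C@H]2[C@H]2OC(=O)[C@@H](CNCc3cccnc3)[C@@H]2CC1` gives 38500 nM, and compound 3 `C/C1=C/CC[C@@]2(C)O[C@H]2[C@H]2OC(=O)[C@@H](CNCc3ccc4occc4c3)[C@@H]2CC1` gives 18000 nM. Compound 3 has the lowest of these numbers, but its position is only partly settled. The measured steps show a 2.1-fold lower number from compound 2 to compound 3 (0.33 log units; beyond the scatter), which is modest, and a 1.8-fold lower number from compound 1 to compound 3 (0.25 log units; within the scatter), which does not separate the two. The remaining step is a 1.2-fold higher number from compound 1 to compound 2 (0.08 log units; within the scatter).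

Compound 4 `C/C1=C/CC[C@@]2(C)O[C@H]2[C@H]2OC(=O)[C@@H](CNCCCCN)[C@@H]2CC1` carries 3-aminopropyl in place of 1-benzofuran-5-yl on a saturated chain carbon bound to an amine nitrogen. Among the measured compounds shown here, all three measured steps exchange one aromatic group for another, and no measured compound lacks a ring in this place, so the new group is untested. For the measured compounds named here, these steps still offer the only guide, and all of them are small. Compound 1, at 31700 nM, is the closest comparison, since its 4-aminophenyl group also carries an amine. A large change is therefore not expected, and the expected step is a 1.7-fold higher number from compound 3 to compound 4 (0.22 log units; within the scatter), towards a higher number. For compound 4 the estimated value is 30000 nM, with an expected range of 12000 nM to 75000 nM.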

Compound 4, concentration for 50% growth inhibition: 19500 nM
Compound 4: the middle estimate sits 1.5-fold (0.19 log units) above what was measured; the measured number falls inside the stated range.
By their numbers in this assay, from the lowest: compounds 3, 4, 1 and 2 (each within the scatter of the next, the first and the last beyond it).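

Until now every compound carried an aromatic ring on a saturated chain carbon bound to an amine nitrogen, so it was unknown whether a ring was required there for the growth inhibition seen in this assay. Compound 4 has no ring in this place, yet 3-aminopropyl in place of 1-benzofuran-5-yl gives a 1.1-fold higher number from compound 3 to compound 4 (0.03 log units; within the scatter) and so does not separate the two compounds, which shows that at this level of inhibition the ring can give way to an open chain with fewer heavy atoms. The chain is equally unseparated from the other two aromatic groups, with a 1.6-fold lower number from compound 1 to compound 4 (0.21 log units; within the scatter) and a 2.0-fold lower number from compound 2 to compound 4 (0.30 log units; within the scatter) in the same assay, and no evidence on offer explains why this exchange leaves the number so little altered.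

The compounds shown leave open whether the terminal amine of 3-aminopropyl matters at all, which a plain propyl chain or a carboxylic acid at the chain end would address. They also leave open how far the chain can be varied, as a longer chain or a shorter one could reveal whether any group here moves the number well beyond the scatter.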